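This account rests on a few compounds, and the source may have more. Where it says the series, first, only, none or still open, it means among the compounds named here.

Measured in an ADME assay on A549 cells (Homo sapiens) for cytotoxicity, read by resazurin assay, with a stated time of 48 h; a lower number here means that less compound is tolerated, a higher number that more compound is tolerated:
compound 1 `O=C(Nc1ccc(NCc2ccccc2)cc1Cl)c1cc(Cl)ccc1O`: 19700 nM
compound 2 `O=C(Nc1ccc(NCc2ccc(Cl)cc2)cc1Cl)c1cc(Cl)ccc1O`: 59700 nM
compound 3 `CN(C)c1ccc(CNc2ccc(NC(=O)c3cc(Cl)ccc3O)c(Cl)c2)cc1`: 24500 nM

Compound 3 cannot be separated from compound 1, as the data show a 1.2-fold higher number from compound 1 to compound 3 (0.09 log units; within the scatter). Compound 2 stands apart, with a 2.4-fold lower number from compound 2 to compound 3 (0.39 log units; beyond the scatter).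

Compound 4 `O=C(Nc1ccc(NCc2cc(F)cc(Cl)c2)cc1Cl)c1cc(Cl)ccc1O` differs from compound 3 as follows: 3-chloro-5-fluorophenyl in place of 4-(dimethylamino)phenyl on a saturated chain carbon bound to a nitrogen on an aromatic ring. In words, 3-chloro-5-fluorophenyl comes in place of 4-(dimethylamino)phenyl on a saturated chain carbon bound to a nitrogen on an aromatic ring.

Within the data shown here, two measured steps bear on this change. Adding dimethylamino to compound 1 gave the small step above, so losing that group alone should matter little. Adding chloro gave a larger one, a 3.0-fold higher number from compound 1 to compound 2 (0.48 log units; beyond the scatter). Among the measured compounds shown here, no measured compound carries a fluoro group, so only part of that chloro step is assumed to carry over. In this assay, a modest move toward a higher number is therefore expected, namely a 1.6-fold higher number from compound 3 to compound 4 (0.21 log units; within the scatter). For compound 4 the estimated value is 40000 nM, with an expected range of 17000 nM to 90000 nM.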

Compound 4, half-maximal cytotoxic concentration: 11100 nM
Compound 4: middle estimate off by 3.6-fold (0.56 log units), on the high side, outside the stated range (below it).
By their numbers in this assay, from the lowest: compounds 4, 1 and 3 (each within the scatter of the next, the first and the last beyond it); then compound 2.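

In this assay, having a chloro on this ring does not by itself bring a higher number: the 3-chloro-5-fluorophenyl group gives a 5.4-fold lower number from compound 2 to compound 4 (0.73 log units; beyond the scatter), and also a 2.2-fold lower number from compound 3 to compound 4 (0.34 log units; beyond the scatter). Against the plain phenyl group the change cannot be told apart from the scatter, with a 1.8-fold lower number from compound 1 to compound 4 (0.25 log units; within the scatter), so among these compounds the 4-chlorophenyl group of compound 2 stands alone at the high end, and halogens on this ring do not act as one class. Nothing at hand explains why these two halogen-bearing rings differ.

As far as these compounds go, it stays open whether the fluoro group, the chloro group's changed place on the ring, or the two together account for the gap to compound 2. A ring with a single fluoro group, a methoxy group or a carboxylic acid at this position would help to separate these possibilities.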